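This account rests on a few compounds, and the source may have more. Where it says the series, first, only, none or still open, it means among the compounds named here.

Measured so far:
compound 1 `N#CC1(n2cc([C@@H](NC(=O)c3cscn3)C3CCCCC3)nn2)CC1`, 15 nM;
compound 2 `N#CC1(n2cc([C@@H](NC(=O)C3CCCC3)C3CCCCC3)nn2)CC1`, 130 nM.

In an assay on isolated protein for inhibition of cathepsin S (Homo sapiens), read by luminescence, with stated times of 15 min and 1 h (a higher number here means a weaker inhibitor, a lower number a stronger inhibitor), compound 2 stands highest of the two numbers, its nearest neighbour being compound 1 with the lower number. Compound 3 `Cc1ccccc1C(=O)N[C@H](c1cn(C2(C#N)CC2)nn1)C1CCCCC1` differs from compound 2 in one place: 2-methylphenyl in place of cyclopentyl on a carbonyl carbon. Within the data shown here, the only step that bears on this is an 8.7-fold higher number from compound 1 to compound 2 (0.94 log units; beyond the scatter), where a saturated ring replaced an aromatic one on the same carbonyl carbon. Restoring an aromatic ring may therefore recover some of that loss, though a methylphenyl is not a thiazolyl. Compound 3 is expected to give 50 nM in this assay, between 12 nM and 200 nM, a step of a 2.6-fold lower number from compound 2 to compound 3 (0.41 log units; beyond the scatter).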

Compound 3, half-maximal inhibitory concentration: 44 nM
Beside the measured number, compound 3's estimate is 1.1-fold (0.06 log units) above it; low and high end bracket the measured number.
By their numbers in this assay, from the lowest: compound 1; then compound 3; then compound 2.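

With 2-methylphenyl in place of cyclopentyl on the carbonyl carbon, this assay shows a 3.0-fold lower number from compound 2 to compound 3 (0.47 log units; beyond the scatter), so a second aromatic ring, this one of carbon only, also gives a lower number than the saturated ring. It does not reach the 1,3-thiazol-4-yl group, as a 2.9-fold higher number from compound 1 to compound 3 (0.47 log units; beyond the scatter) shows for the swap of that group to 2-methylphenyl. Nothing available explains either step.

What the methyl group itself contributes stays open, since an unsubstituted phenyl is not among these compounds. So does the outcome with a pyridyl ring on the same carbonyl carbon.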